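Nitro in place of methyl on the outer aromatic ring

This account rests on a few compounds, and the source may have more. Where it says the series, first, only, none or still open, it means among the compounds named here.

Three compounds share one core. Compound 1 `O=c1ccoc2cc(OCc3cn(Cc4ccccc4)nn3)ccc12` gives in a functional assay on QGY7701 cells (Homo sapiens) for cytotoxicity, read by MTT assay, with a stated time of 48 h (on this read-out higher numbers stand for weaker inhibition and lower numbers for stronger inhibition), only a limit, > 100000 nM (the limit of > 100000 nM in this assay, at which 1 of the 3 values shown sits). Compound 2 `Cc1cccc(Cn2cc(COc3ccc4c(=O)ccoc4c3)nn2)c1` gives in this assay 22400 nM, the smaller of the two recorded numbers, and compound 3 `O=c1ccoc2cc(OCc3cn(Cc4ccc(Cl)cc4)nn3)ccc12` gives 41700 nM, so that a 1.9-fold higher number from compound 2 to compound 3 (0.27 log units; within the scatter). The steps of an at least 4.4-fold lower number from compound 1 to compound 2 (0.64 log units; beyond the scatter) and an at least 2.3-fold lower number from compound 1 to compound 3 (0.37 log units; beyond the scatter) show that a methyl or a chloro on that ring gives a recordable number. Compound 4 `O=c1ccoc2cc(OCc3cn(Cc4cccc([N+](=O)[O-])c4)nn3)ccc12` differs from compound 2 by nitro in place of methyl on an aromatic carbon. Among the measured compounds shown here, no measured step puts a nitro there, so compound 4 is expected to give about 25000 nM, between 8000 nM and 80000 nM. The estimated step of a 1.1-fold higher number from compound 2 to compound 4 (0.05 log units; within the scatter) is expected to stay within the scatter.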

Compound 4, half-maximal inhibitory concentration: 14100 nM
Estimate against measurement, compound 4: 1.8-fold (0.25 log units) above, and the stated range covers the measured number.
By their numbers in this assay, from the lowest: compounds 4, 2 and 3 (each within the scatter of the next, the first and the last beyond it). At a limit, above all of these: compound 1.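

In this assay, nitro in place of methyl on this aromatic carbon stays within the scatter: a 1.6-fold lower number from compound 2 to compound 4 (0.20 log units; within the scatter). The 3-nitrophenyl group does, however, separate from the 4-chlorophenyl group, which the 3-methylphenyl group did not: a 3.0-fold lower number from compound 3 to compound 4 (0.47 log units; beyond the scatter). The step from hydrogen to nitro, an at least 7.0-fold lower number from compound 1 to compound 4 (0.85 log units; beyond the scatter), rests on a limit: the limit of > 100000 nM in this assay, at which 1 of the 4 values shown sits.

Going by these compounds, whether an amine or a carboxylic acid on this carbon would give a number near these stays open. So does what lies behind these steps.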